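The compounds below may be only part of what the source reports. "The series", "measured", "known", "first", "only" and "open" are said of these compounds alone.

Two sulfonyl compounds sharing one core have been tested in an assay for inhibition of methylcytosine dioxygenase TET2 (Homo sapiens), read by mass spectrometry, with stated times of 30 min and 1 h; a higher number here means a weaker inhibitor, a lower number a stronger inhibitor. Compound 1 `CC(C)OS(=O)(=O)c1ccc(F)c2ncc(I)cc12` carries an isopropoxy group on the sulfonyl sulfur, and in this assay compound 1 gives only a limit, > 200000 nM. Compound 2 `NS(=O)(=O)c1ccc(F)c2ncc(I)cc12` has an amino group in that position, and in this assay compound 2 gives 86600 nM. Among the measured compounds shown here, compound 2 thus holds the only actual number among the two results. The other result, that of compound 1, is a limit: the limit of > 200000 nM in this assay, at which 1 of the 2 values shown sits. For the measured compounds named here, the single measured step, an at least 2.3-fold lower number from compound 1 to compound 2 (0.36 log units; beyond the scatter), runs toward a stronger inhibitor when amino replaces isopropoxy. Compound 3 `O=S(=O)(c1ccc(F)c2ncc(I)cc12)N1CCCC1` has not yet been measured. It differs from compound 2 in one place: pyrrolidin-1-yl in place of amino on a sulfonyl sulfur. Going by the values given here, the only step that bears on this change, an at least 2.3-fold lower number from compound 1 to compound 2 (0.36 log units; beyond the scatter), moved toward stronger inhibition when isopropoxy gave way to amino; here amino gives way to pyrrolidin-1-yl, so a step back toward a weaker inhibitor, of similar modest size, is expected, with a real chance that only a limit is reported. For compound 3 the estimate in this assay is 150000 nM, between 50000 nM and 450000 nM, which means an expected step of a 1.7-fold higher number from compound 2 to compound 3 (0.24 log units; within the scatter).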

Compound 3, half-maximal inhibitory concentration: > 200000 nM
Compound 3 was reported as a limit (the forecaster's own chance of this, stated with the estimate: 40%); at least 1.3-fold (0.12 log units) between middle value and limit.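

Putting pyrrolidin-1-yl in place of amino on the sulfonyl sulfur gives an at least 2.3-fold higher number from compound 2 to compound 3 (0.36 log units; beyond the scatter), so in this assay a nitrogen attached to the sulfur is not enough on its own to keep the measurable inhibition of compound 2. This change swaps the small amino group, which carries a hydrogen-bond donor, for a five-membered ring with no donor, and the weaker result shows that the group at this position matters, even among nitrogen groups. Compound 1 and compound 3 both give only limits, so the step between them cannot be read, and compound 2 remains the only compound with an actual number: the limit of > 200000 nM in this assay, at which 2 of the 3 values shown sit.

The compounds shown do not separate the loss of the donor from the gain of the ring, since both arrive in the same change. A methylamino group, a dimethylamino group or an open diethylamino group on the sulfonyl sulfur would help to tell these two apart, and would show how much can be added to the amino nitrogen before only a limit is reported.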